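From 4-Methylpiperidin-1-yl to 4-Methylpiperazin-1-yl

The compounds below may be only part of what the source reports. "The series", "measured", "known", "first", "only" and "open" are said of these compounds alone.

Compound 1 `COc1cc2c(Oc3ccc(NC(=O)c4cn(-c5ccccc5)nn4)cc3F)ccnc2cc1OCCCN1CCCCC1` and compound 2 `COc1cc2c(Oc3ccc(NC(=O)c4cn(-c5ccccc5)nn4)cc3F)ccnc2cc1OCCCN1CCC(C)CC1` share one core and differ only in the saturated ring at the end of the chain. In a functional assay on MKN-45 cells (Homo sapiens) for cytotoxicity, read by MTT assay, with a stated time of 72 h (a lower number here means a stronger inhibitor, a higher number a weaker inhibitor), compound 1 gives 100 nM, and compound 2 gives 90 nM. Among the measured compounds shown here, the step is a 1.1-fold lower number from compound 1 to compound 2 (0.05 log units; within the scatter), so compound 2 holds the lowest of the two numbers while its only neighbour, compound 1, sits within the scatter, and the two cannot be told apart. Compound 3 `COc1cc2c(Oc3ccc(NC(=O)c4cn(-c5ccccc5)nn4)cc3F)ccnc2cc1OCCCN1CCN(C)CC1` has not been measured; its change from compound 2 is 4-methylpiperazin-1-yl in place of 4-methylpiperidin-1-yl on a saturated chain carbon, three bonds along the chain from an oxygen on an aromatic ring. For the measured compounds named here, the one measured step touches the same saturated ring but alters a different part of it, so it guides only loosely, showing that a small change there left the number essentially unchanged. Going by the values given here, no measured step covers a ring carbon replaced by nitrogen, so a step no larger than the scatter is expected, a 1.1-fold higher number from compound 2 to compound 3 (0.05 log units; within the scatter). Compound 3 is therefore estimated at 100 nM in this assay, between 40 nM and 250 nM.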

Compound 3, half-maximal inhibitory concentration: 60 nM
Beside the measured number, compound 3's estimate is 1.7-fold (0.22 log units) above it, within the range that was stated.
By their numbers in this assay, from the lowest: compounds 3, 2 and 1 (each within the scatter of the next).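

Exchanging 4-methylpiperidin-1-yl for 4-methylpiperazin-1-yl gives a 1.5-fold lower number from compound 2 to compound 3 (0.18 log units; within the scatter) in this assay, and exchanging piperidin-1-yl for 4-methylpiperazin-1-yl gives a 1.7-fold lower number from compound 1 to compound 3 (0.22 log units; within the scatter). The earlier pair showed only that a methyl on a ring carbon left the number within the scatter; now a ring carbon replaced by nitrogen, on a saturated chain carbon three bonds along the chain from an oxygen on an aromatic ring, also stays within it. Nothing available speaks to what lies behind these numbers.

From the compounds shown here alone, all three compounds end in a six-membered saturated ring, so it remains open how morpholin-4-yl or an open-chain dimethylamino group would read here. Also open, going by these compounds, is whether the same exchange would read alike on a shorter chain, as in 2-(4-methylpiperazin-1-yl)ethyl.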